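Pyrrolopyrimidine aminocyclohexyl series: hepatocyte clearance notes

The source may hold more compounds than are shown below. What is called first, only, known or untested is meant among the compounds shown, and "the series" means these compounds.

Compound 1 `CN(C)[C@H]1CC[C@H](Nc2ncnc3[nH]cc(C(F)(F)F)c23)CC1` carries a dimethylamino group on the saturated ring and, in an ADME assay on cells (Hepatocyte, Rattus norvegicus) for metabolic stability (a lower number here means slower removal, a higher number faster removal of the compound), compound 1 gives 66 uL/min. Among the compounds with values here, compound 2 `CC(=O)N1CCN([C@H]2CC[C@H](Nc3ncnc4[nH]cc(C5CCOCC5)c34)CC2)CC1` replaces that group with 4-acetylpiperazin-1-yl and changes the substituent on the shared core; in this assay compound 2 gives 4.6 uL/min, the lowest of the two numbers so far, and the gap to compound 1 is beyond the scatter. Compound 3 `CN(C)C(=O)C1CCN([C@H]2CC[C@H](Nc3ncnc4[nH]cc(C5CCOCC5)c34)CC2)CC1` keeps the core and substituent of compound 2 and differs only on the saturated ring carbon (4-(dimethylcarbamoyl)piperidin-1-yl in place of 4-acetylpiperazin-1-yl on a saturated ring carbon). Within the data shown here, no measured pair shows this exchange, so no step is known for it; with the same core as compound 2 and a second amide-bearing six-membered ring in place of the first, the step from compound 2 to compound 3 is expected to be none beyond the scatter, a 1.3-fold higher number from compound 2 to compound 3 (0.12 log units; within the scatter). Compound 3 is therefore estimated at 6 uL/min, with an expected range from 2.5 uL/min to 15 uL/min.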

Compound 3, intrinsic clearance in a liver preparation (reported as CLH), per the amount of preparation that the assay uses in the Hepatocyte assay: 2 uL/min
For compound 3 the middle estimate is 3.0-fold (0.48 log units) above the measured one; the measured number lies below the stated range.
By their numbers in the Hepatocyte assay, from the lowest: compound 3; then compound 2; then compound 1.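

In the Hepatocyte assay, 4-(dimethylcarbamoyl)piperidin-1-yl in place of 4-acetylpiperazin-1-yl gives a 2.3-fold lower number from compound 2 to compound 3 (0.36 log units; beyond the scatter), the first change read at a single place, since compound 1 and compound 2 differ in two. This saturated ring carbon therefore still moves clearance when one amide-bearing six-membered ring replaces another, even from an already low number. In a physicochemical assay for lipophilicity, using the shake flask method, at pH 7.4 (on this read-out higher numbers stand for higher lipophilicity and lower numbers for lower lipophilicity), compound 2 gives 1.3 and compound 3 gives -0.1, so the slower removal comes with lower lipophilicity: the measured distribution coefficient of compound 2, 1.3, and of compound 3, -0.1, a number 1.40 log units lower (beyond the scatter)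

As far as these compounds go, this single pair cannot separate lipophilicity from any other difference between the two groups, and a carboxylic acid or a hydroxyl group in place of the dimethylcarbamoyl remains open. Also open, from the compounds shown here alone, is whether the step holds with the trifluoromethyl substituent of compound 1 on the shared core.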